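Moving the Chlorine: From Compound 1 to Compound 3

This account rests on a few compounds, and the source may have more. Where it says the series, first, only, none or still open, it means among the compounds named here.

Compound 1, with structure `CC1=NN(c2cccc(Cl)c2)C(=O)C12C=CC(=O)C=C2c1ccc(C)cc1`, was tested in a functional assay on MDA-MB-231 cells (Homo sapiens) for antiproliferative activity, read by CCK-8 assay, with a stated time of 72 h (on this read-out lower numbers stand for stronger inhibition and higher numbers for weaker inhibition), and gave 3820 nM. Among the two numbers measured so far this is the lowest. The other compound, compound 2 with structure `CC1=NN(c2ccccc2)C(=O)C12C=CC(=O)C=C2c1ccccc1`, gave 27400 nM, a gap that lies beyond the usual scatter of this kind of measurement.

Compound 3, with structure `CC1=NN(c2ccc(Cl)cc2)C(=O)C12C=CC(=O)C=C2c1ccc(C)cc1`, has not yet been measured. Its difference from compound 1 is 4-chlorophenyl in place of 3-chlorophenyl on an amide-type nitrogen in a ring. Among the measured compounds shown here, no pair of measured compounds shows what this kind of change does here, so there is no step to lean on. The expectation is that the number stays close, with a step of a 1.1-fold lower number from compound 1 to compound 3 (0.04 log units; within the scatter) that is estimated to fall within the scatter, in no clear direction. For compound 3 the estimated value is 3500 nM, with a range from 1200 nM to 10000 nM.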

Compound 3, half-maximal inhibitory concentration: 14300 nM
The estimate for compound 3 lay 4.1-fold (0.61 log units) below the measured number; measured number above the stated range.
By their numbers in this assay, from the lowest: compound 1; then compounds 3 and 2 (each within the scatter of the next).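

In this assay, among the compounds shown here, putting 4-chlorophenyl in place of 3-chlorophenyl on the amide-type nitrogen gives a 3.7-fold higher number from compound 1 to compound 3 (0.57 log units; beyond the scatter) and this is the first single-place comparison. Compound 1 and compound 3 hold the same atoms, joined differently, so the step shows that this position is not indifferent to where the chlorine sits on the ring. No measurement in hand explains why the number moves in this direction.

As far as these compounds go, compound 2 differs from compound 1 in more than one place, so what the chlorine itself contributes remains open. Also open, from the compounds shown here alone, is how a ring carrying a methoxy group or an amine in place of the chlorine would fare on the same nitrogen.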